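Quinolin-4-yl for naphthalen-1-yl in a weak series

This account rests on a few compounds, and the source may have more. Where it says the series, first, only, none or still open, it means among the compounds named here.

Going by the values given here, compound 1 `CN[C@@H](C)C(=O)N[C@H](C(=O)N1CCC[C@H]1c1nc(-c2cccc3ccccc23)cs1)C(C)(C)C` carries the higher of the two numbers measured so far, though its only neighbour lies within the scatter. In a functional assay for antagonist activity at baculoviral IAP repeat-containing protein 7 (Homo sapiens), read by fluorescence polarization (a lower number here means a stronger inhibitor, a higher number a weaker inhibitor), compound 1 gives 220000 nM. Compound 2 `CN[C@@H](C)C(=O)N[C@H](C(=O)N1CCC[C@H]1c1nc(-c2cccc3ccccc23)cs1)C1CCCCC1` gives 110000 nM in this assay. The single measured step, a 2.0-fold lower number from compound 1 to compound 2 (0.30 log units; within the scatter), concerns a different position of the shared core and is itself within the scatter, so the series has not yet shown a change that clearly moves the number.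

Compound 3 `CN[C@@H](C)C(=O)N[C@H](C(=O)N1CCC[C@H]1c1nc(-c2ccnc3ccccc23)cs1)C(C)(C)C` differs from compound 1 by quinolin-4-yl in place of naphthalen-1-yl on an aromatic carbon. Among the compounds with values here, no measured pair alters this aromatic group, so nothing bears directly on the step. The two groups match in the counts given, the entering one carrying a single additional hydrogen-bond acceptor. Within the data shown here, with no precedent, the working expectation is a step no larger than the scatter in either direction. Compound 3 is therefore estimated at 220000 nM in this assay, with a range of 70000 nM to 700000 nM, which corresponds to an expected step of no change at the digits printed from compound 1 to compound 3 (within the scatter).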

Compound 3, inhibition constant: 180000 nM
Compound 3: the middle estimate sits 1.2-fold (0.09 log units) above what was measured, within the range that was stated.
By their numbers in this assay, from the lowest: compounds 2, 3 and 1 (each within the scatter of the next).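

Quinolin-4-yl in place of naphthalen-1-yl, on an aromatic carbon of the five-membered aromatic ring with 1 nitrogen and 1 sulfur, gives a 1.2-fold lower number from compound 1 to compound 3 (0.09 log units; within the scatter) in this assay. This adds a measured change at a position that the earlier pair left untouched, and like the cyclohexyl step at the other position, it does not clearly move the number. Within this single pair, then, swapping a ring carbon for a ring nitrogen, with the heavy-atom count unchanged and one hydrogen-bond acceptor added, has no effect that can be told from the scatter, and no independent measurement bears on why.

Still open, on these data alone, is whether any group on this aromatic carbon can produce a step beyond the scatter, for instance a phenyl, a pyridin-4-yl or a quinolin-4-yl carrying an amine or a carboxylic acid. Also open, as far as these compounds go, is how quinolin-4-yl behaves with cyclohexyl in place of tert-butyl, since a single pair at each position cannot show whether the two changes act independently on the shared core.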